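Sulfonamide variation in a CXCR4 series: compound 4

The compounds below may be only part of what the source reports. "The series", "measured", "known", "first", "only" and "open" are said of these compounds alone.

Measured so far:
compound 1 `O=C(NCc1ccc(CNS(=O)(=O)c2ccc(-c3ccc(F)cc3)cc2)cc1)c1ccc(F)cc1` gives 100 nM in an assay on MDA-MB-231 cells for binding affinity to C-X-C chemokine receptor type 4 (Homo sapiens), read by fluorescence and microscopy, with stated times of 10 min and 30 min; on this read-out higher numbers stand for an effect only at larger amounts of compound and lower numbers for an effect already at smaller amounts
compound 2 `O=C(NCc1ccc(CNS(=O)(=O)c2ccc3c(c2)CCO3)cc1)c1ccc(F)cc1` gives 10 nM in this assay
compound 3 `O=C(NCc1ccc(CNS(=O)(=O)c2ccc(Cl)cc2)cc1)c1ccc(F)cc1` gives 100 nM in this assay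

Compound 2 stands lowest of the three values; its nearest neighbour is compound 1, no change at the digits printed from compound 1 to compound 3 (within the scatter), and the wider gap is a 10-fold higher number from compound 2 to compound 3 (1.00 log units; beyond the scatter).

Compound 4 `O=C(NCc1ccc(CNS(=O)(=O)c2ccc(F)cc2)cc1)c1ccc(F)cc1` is the next variation. Relative to compound 2: a group of 7 heavy atoms (6 carbon, 1 fluorine; one six-membered aromatic ring of carbon only) in place of a group of 9 heavy atoms (8 carbon, 1 oxygen; one five-membered non-aromatic ring with 1 hetero atom, one six-membered aromatic ring of carbon only), on a sulfonyl sulfur.

Within the data shown here, two measured steps bear on this. Replacing the larger group on the sulfonyl sulfur by a single substituted phenyl gave a 10-fold higher number from compound 2 to compound 3 (1.00 log units; beyond the scatter), and exchanging the substituent on that phenyl gave no change at the digits printed from compound 1 to compound 3 (within the scatter). The step into compound 4 is therefore expected to be of the same kind as the step into compound 3, with a higher number than compound 2 and a value near those of compound 1 and compound 3. For compound 4 the estimate is 100 nM (range 30 nM to 300 nM), meaning an expected step of a 10-fold higher number from compound 2 to compound 4 (1.00 log units; beyond the scatter).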

Compound 4, effective concentration (reported as EC, without a stated level of effect): 1 nM
Compound 4: middle estimate off by 100-fold (2.00 log units), on the high side; measured number below the stated range.
By their numbers in this assay, from the lowest: compound 4; then compound 2; then compounds 1 and 3 (each within the scatter of the next).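

Single-atom exchange on the aromatic carbon matters far more than the earlier compounds suggested: fluoro in place of chloro gives a 100-fold lower number from compound 3 to compound 4 (2.00 log units; beyond the scatter), and fluoro in place of 4-fluorophenyl gives a 100-fold lower number from compound 1 to compound 4 (2.00 log units; beyond the scatter), although chloro and 4-fluorophenyl themselves showed no change at the digits printed from compound 1 to compound 3 (within the scatter). 4-Fluorophenyl on the sulfonyl sulfur also gives a 10-fold lower number from compound 2 to compound 4 (1.00 log units; beyond the scatter), so a single substituted phenyl at this position is not in itself a loss. Nothing available accounts for the sharp separation of fluoro from chloro. As far as these compounds go, whether a methyl, a methoxy or an amine on that aromatic carbon would keep a number as low as that of fluoro remains open.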